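Boron-bearing replacement on an amine nitrogen of compound 1

A few compounds are considered here, and "the series" means these few. Any claim that something is new, unique, unknown or untested is made for them only; others in the source may bear on it.

- compound 1 `CC(C)CN(NC(=O)OCc1ccccc1)C(=O)CN(Cc1ccccc1)NC(=O)Cc1cccc(Br)c1`: 15800 nM
- compound 2 `CC(C)CN(CC(=O)N(Cc1ccccc1)NC(=O)OCc1ccccc1)/N=C/c1cccc(B(O)O)c1`: 19900 nM

In a functional assay on B16 cells (Mus musculus) for inhibition (a higher number here means a weaker inhibitor, a lower number a stronger inhibitor), compound 1 lies within the scatter of compound 2, so the two numbers shown cannot be ranked. Compound 3 `CC(C)CN(NC(=O)OCc1ccccc1)C(=O)CN(Cc1ccccc1)/N=C/c1ccc(B(O)O)cc1` is not yet measured. Within the data shown here, it keeps the core of compound 1 and carries a group of 11 heavy atoms (7 carbon, 1 boron, 1 nitrogen, 2 oxygen; one six-membered aromatic ring of carbon only) in place of a group of 11 heavy atoms (8 carbon, 1 nitrogen, 1 oxygen, 1 bromine; one six-membered aromatic ring of carbon only), on an amine nitrogen as its one change. The entering group contains boron. Compound 2 also contains boron and gives 19900 nM within the scatter of compound 1. Among the measured compounds shown here, no measured step isolates this replacement, so that comparison is weak support. No shift beyond the scatter is expected in this assay for this change. The estimated 1.1-fold lower number from compound 1 to compound 3 (0.05 log units; within the scatter) is expected to stay within the scatter. For compound 3 the estimated value is 14000 nM with an expected range from 4000 nM to 40000 nM in this read-out.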

Compound 3, half-maximal inhibitory concentration: 39300 nM
Estimate against measurement, compound 3: 2.8-fold (0.45 log units) below; measured number inside the range.
By their numbers in this assay, from the lowest: compounds 1, 2 and 3 (each within the scatter of the next, the first and the last beyond it).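

In this assay, the replacement on an amine nitrogen now has a direct reading: the group of 11 heavy atoms holding boron, in place of the group of 11 heavy atoms holding bromine, gives a 2.5-fold higher number from compound 1 to compound 3 (0.40 log units; beyond the scatter) on the core of compound 1. The step is modest, but it shows that this position responds to this change, which compound 2, differing from compound 1 in more than one place, could not show. No measurement shown bears on the cause of this step.

The entering and leaving groups differ in more than one feature, so the step cannot yet be assigned to the boron atom itself. A carboxylic acid in place of the boron-bearing function, or an unsubstituted phenyl ring on the same link, would help separate these contributions.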